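Following One Change From Compound 2 to Compound 3

The source may report more compounds than this note shows. Statements on the series, on what has been measured and on what is new or still open speak of the compounds shown alone.

Among the measured compounds shown here, compound 2 `C/N=C(/NC#N)NCCCCn1nc(-c2ccccc2)cc(C)c1=O` is the only compound here with a real number in a functional assay on the whole organism (stomach) with Rattus norvegicus as the target; on this read-out lower numbers stand for an effect already at smaller amounts and higher numbers for an effect only at larger amounts of compound: in this assay compound 2 gives 60.8 mg/kg. Compound 1 `C/N=C(/NC#N)NCCCn1nc(-c2ccccc2)ccc1=O` sits at the limit of > 100 mg/kg in this assay, at which 1 of the 2 values shown sits, which is a limit of the assay and not a number; compound 1 gives > 100 mg/kg. Compound 3 `C/N=C(/NC#N)NCCCn1nc(-c2ccccc2)cc(C)c1=O` is not yet measured and differs from compound 2 by a group of 7 heavy atoms (3 carbon, 4 nitrogen; no ring) in place of a group of 8 heavy atoms (4 carbon, 4 nitrogen; no ring), on a saturated chain carbon, three bonds along the chain from an aromatic nitrogen. For the measured compounds named here, no measured pair shares this change. The step from compound 2 to compound 3 is expected to raise the dose by a 1.5-fold higher number from compound 2 to compound 3 (0.17 log units; within the scatter), beyond the scatter. Compound 3 is estimated at 90 mg/kg, between 40 mg/kg and 200 mg/kg.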

Compound 3, dose for half-maximal effect: > 100 mg/kg
Compound 3: a limit, no number; the forecaster's own chance of this, stated with the estimate: 45%; middle value at least 1.1-fold (0.04 log units) from the limit.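

On a saturated chain carbon, three bonds along the chain from an aromatic nitrogen, the group of 7 heavy atoms in place of the group of 8 gives an at least 1.6-fold higher number from compound 2 to compound 3 (0.21 log units; that floor lies within the scatter) in this assay. Among the compounds shown here, this is the first step readable at this position, but it is only a floor, so the real size of the change stays unknown. Compound 3 joins compound 1 at a limit, which is not a number: the limit of > 100 mg/kg in this assay, at which 2 of the 3 values shown sit.

The step from compound 1 to compound 3, methyl in place of hydrogen on an aromatic carbon, cannot be read. On these data alone, whether a longer chain than that of compound 2 would give a lower number also stays open.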